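From 1H-pyrrol-2-yl to thiophen-2-yl on a shared core

The compounds below may be only part of what the source reports. "The series", "measured", "known", "first", "only" and "open" are said of these compounds alone.

In a functional assay on BGC-823 cells (Homo sapiens) for inhibition, read by sulforhodamine B assay, with a stated time of 3 days (on this read-out lower numbers stand for stronger inhibition and higher numbers for weaker inhibition), compound 1 (`O=C1Nc2ccc(F)cc2/C1=C\C(=O)c1ccc(O)cc1F`) gives 6120 nM and compound 2 (`O=C1Nc2ccc(F)cc2/C1=C\C(=O)c1ccc[nH]1`) gives 6420 nM on the same scale, so the two stand level within the scatter of repeated measurements. Compound 3 (`O=C1Nc2ccc(F)cc2/C1=C\C(=O)c1cccs1`) has not been measured yet. It has thiophen-2-yl in place of 1H-pyrrol-2-yl on a carbonyl carbon. Going by the values given here, no measured pair shows this swap on its own, so any forecast is indirect. Compound 1 carries another group on that carbonyl carbon and still gives 6120 nM as its result, level with compound 2. A change beyond the scatter is therefore not expected in either direction, and the expected move is a 1.2-fold lower number from compound 2 to compound 3 (0.07 log units; within the scatter) in size. For compound 3 the estimated value is 5500 nM within a likely range from 2200 nM to 13000 nM in this assay once tested.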

Compound 3, half-maximal inhibitory concentration: 7750 nM
Compound 3: the middle estimate sits 1.4-fold (0.15 log units) below what was measured; the measured number falls inside the stated range.
By their numbers in this assay, from the lowest: compounds 1, 2 and 3 (each within the scatter of the next).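

In this assay, going by these compounds alone, the swap of 1H-pyrrol-2-yl for thiophen-2-yl on the carbonyl carbon gives a 1.2-fold higher number from compound 2 to compound 3 (0.08 log units; within the scatter), the first direct reading of this change. The two compounds therefore stand level, even though the swap exchanges the ring nitrogen for sulfur and removes the hydrogen-bond donor counted on 1H-pyrrol-2-yl. At this position, then, that donor is not needed to keep the number in this range, at least for this pair of five-membered rings, and no measurement shown here accounts for the two compounds standing level.

Going by these compounds, all three compounds carry an aromatic ring on that carbonyl carbon, so it remains open whether an amine or a longer chain there would give a number beyond the scatter. A furan-2-yl group would test one further five-membered ring.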